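Replacing the furan of compound 2

The source may report more compounds than this note shows. Statements on the series, on what has been measured and on what is new or still open speak of the compounds shown alone.

In a functional assay on ECa-109 cells for antiproliferative activity against ECa-109 cell line (Homo sapiens), read by MTT assay, with a stated time of 72 h (on this read-out higher numbers stand for weaker inhibition and lower numbers for stronger inhibition), compound 1 (`C/C(=N\NC(=O)c1cccc(S(=O)(=O)N2CCOCC2)c1)c1ccc(O)cc1`) gives 88300 nM as its half-maximal inhibitory concentration. For compound 2 (`O=C(N/N=C/c1ccco1)c1cccc(S(=O)(=O)N2CCOCC2)c1`) the assay returns > 100000 nM as its result, and this is a limit and not a number. Compound 2 therefore has no exact place on the scale, and any step measured from it stays loose.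

Compound 3 (`O=C(N/N=C/c1cc(Cl)ccc1O)c1cccc(S(=O)(=O)N2CCOCC2)c1`) keeps the shared core of compound 2 but carries 5-chloro-2-hydroxyphenyl in place of furan-2-yl on a carbon with a double bond to nitrogen. Going by the values given here, no measured pair in this small set differs in one place, so there is no direct precedent for the size of this step. Compound 1 at 88300 nM does show that a member of this family can return a real number in the assay. A move towards stronger inhibition, meaning a lower number, is therefore expected. The estimated step of an at least 5.0-fold lower number from compound 2 to compound 3 (0.69 log units; beyond the scatter) is expected to lie beyond the usual scatter of repeated measurements. Compound 3 is estimated at 20000 nM in this assay, with an expected range from 4000 nM to 90000 nM for its measurement.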

Compound 3, half-maximal inhibitory concentration: 2840 nM
Compound 3: middle estimate off by 7.0-fold (0.85 log units), on the high side, outside the stated range (below it).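

In this assay, the group on the carbon with a double bond to nitrogen turns out to matter a great deal: placing 5-chloro-2-hydroxyphenyl there in place of furan-2-yl gives an at least 35-fold lower number from compound 2 to compound 3 (1.54 log units; beyond the scatter). Going by these compounds alone, this is the first change in the set that can be read in one place, and it is large, taking the shared core from a result with no exact place on the scale to a real number. The true size of the step stays open at one end, because one of its two ends is a limit and not a number: the limit of > 100000 nM in this assay, at which 1 of the 3 values shown sits.

The swap changes the ring and adds the chlorine and the hydroxy group all at once, so the compounds shown cannot tell which of these parts carries the step. On these data alone, a plain phenyl ring, a phenyl ring with only the chlorine or only the hydroxy group, or one with a methoxy group or an amine in place of the hydroxy group would each separate these parts, and how such groups would behave here remains open.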